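The source may report more compounds than this note shows. Statements on the series, on what has been measured and on what is new or still open speak of the compounds shown alone.

Measured so far:
compound 1, `CC(C)(O)c1nc(-c2cccc(CNC(=O)c3ccc(-c4ccccc4)nc3)c2)no1`, 808 nM;
compound 2, `CC(C)(O)c1nc(-c2cccc(CNC(=O)c3ccc(-c4ccccn4)nc3)c2)no1`, 328 nM;
compound 3, `c1ccc(-c2ncc(-c3cnc(-c4ccccn4)nc3)[nH]2)cc1`, 5060 nM.

In an assay on isolated protein for inhibition of Hematopoietic prostaglandin D synthase (Homo sapiens), read by ELISA (a higher number here means a weaker inhibitor, a lower number a stronger inhibitor), compound 2 gives 328 nM and compound 1 gives 808 nM. The step between them is phenyl in place of pyridin-2-yl on an aromatic carbon; it made a 2.5-fold higher number from compound 2 to compound 1 (0.39 log units; beyond the scatter). Compound 3 stands apart: in this assay compound 3 gives 5060 nM, and the difference between its core and the core of compound 2 is not broken down here.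

Compound 4, `c1ccc(-c2ncc(-c3cnc(-c4ccccc4)[nH]3)cn2)cc1`, is not yet measured. Its change from compound 3 is phenyl in place of pyridin-2-yl on an aromatic carbon. The place is not identical to the earlier one: there the ring carried one nitrogen and the group sat next to the ring nitrogen, here the ring carries two nitrogen atoms and the group sits between two ring nitrogen atoms; so it is the same kind of change, not the same. Because the earlier step was a 2.5-fold higher number from compound 2 to compound 1 (0.39 log units; beyond the scatter), compound 4 is expected to show a similar modest step, a 2.0-fold higher number from compound 3 to compound 4 (0.30 log units; within the scatter). The estimate for compound 4 in this assay is 10000 nM, between 4000 nM and 30000 nM.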

Compound 4, half-maximal inhibitory concentration: 59 nM
Compound 4: middle estimate off by 170-fold (2.23 log units), on the high side, outside the stated range (below it).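

Phenyl in place of pyridin-2-yl gave an 86-fold lower number from compound 3 to compound 4 (1.93 log units; beyond the scatter) in this assay. The change therefore does not carry from one core to the other in size or in direction: the same change on two cores in this assay, a 2.5-fold higher number (0.39 log units; beyond the scatter) from compound 2 to compound 1 and an 86-fold lower number (1.93 log units; beyond the scatter) from compound 3 to compound 4, 210-fold (2.32 log units) apart, beyond the scatter of two such steps

This shows that the outcome of the swap depends on its setting, but two pairs do not show which feature of the setting matters, since the cores differ and so does the ring carrying the group.

The compounds shown leave open which part of the core sets the direction of the step. They also leave open how an amine or a carboxylic acid on that ring would compare with phenyl on the core of compound 4.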